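A few compounds are considered here, and "the series" means these few. Any claim that something is new, unique, unknown or untested is made for them only; others in the source may bear on it.

Working notes, chain homologues on the shared core. In an assay on RBL-1 cells for inhibition of Polyunsaturated fatty acid 5-lipoxygenase (Rattus norvegicus) (a higher number here means a weaker inhibitor, a lower number a stronger inhibitor), compound 1 `CC(=O)N(O)C(C)c1ccc(OCc2ccccc2)cc1` gives 280 nM, compound 2 `CC(c1ccc(OCc2ccccc2)cc1)N(O)C=O` gives 940 nM and compound 3 `CCCCOc1ccc(C(CC)N(O)C(C)=O)cc1` gives 740 nM. For the measured compounds named here, the only single-point step so far, a 3.4-fold higher number from compound 1 to compound 2 (0.53 log units; beyond the scatter), changes the carbonyl substituent and not the chain. Compound 3 stands second highest of the three numbers in this assay: compound 2 lies within the scatter of it, while compound 1 lies lower, beyond it; compounds 1 and 3 differ in more than one place, so their gap is read only as the two values show. Compound 4 `CCCCOc1ccc(C(CCCC)N(O)C(C)=O)cc1` carries ethyl in place of hydrogen on a saturated chain carbon, three bonds along the chain from an amide-type nitrogen and an aromatic carbon. Going by the values given here, no measured step touches that chain, and the one known step sits elsewhere, so nothing supports a shift beyond the scatter. Compound 4 is therefore expected to show a 1.1-fold lower number from compound 3 to compound 4 (0.02 log units; within the scatter), estimated at 700 nM in this assay, within 250 nM to 2000 nM.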

Compound 4, half-maximal inhibitory concentration: 570 nM
The estimate for compound 4 lay 1.2-fold (0.09 log units) above the measured number, within the range that was stated.
By their numbers in this assay, from the lowest: compound 1; then compounds 4, 3 and 2 (each within the scatter of the next).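

For the compounds shown here, the first measured step on this chain, a 1.3-fold lower number from compound 3 to compound 4 (0.11 log units; within the scatter) in this assay, shows that going from ethyl to butyl at this position produces no shift beyond the scatter. This single pair therefore gives the position a first reading: it carries the longer chain with the number held within the scatter. Nothing available explains this result.

On these data alone, whether a chain longer than butyl, or one ending in an amine or a carboxylic acid, would shift the number stays open. Also open, as far as these compounds go, is whether hydrogen in place of methyl on the carbonyl carbon has the same size of effect on compound 4.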